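This account rests on a few compounds, and the source may have more. Where it says the series, first, only, none or still open, it means among the compounds named here.

Working notes on the dihydropyrimidinone series in an assay for inhibition of beta-glucuronidase (Bos taurus), read by spectrophotometry, with a stated time of 30 min; a lower number here means a stronger inhibitor, a higher number a weaker inhibitor.

Three compounds of the shared core carry a single ring at the same position. Compound 1 (`COC(=O)C1=C(C)NC(=O)NC1c1ccccc1`) has that ring unsubstituted; in this assay compound 1 gives "not active" (no number reported), with no number reported. Compound 2 (`COC(=O)C1=C(C)NC(=O)NC1c1ccc(OC)cc1`) carries a methoxy on that ring; in this assay compound 2 gives 59200 nM. Compound 3 (`COC(=O)C1=C(C)NC(=O)NC1c1ccc(OC)c(OCc2ccccc2)c1`) carries the same methoxy and a benzyloxy besides; in this assay compound 3 gives "not active" (no number reported), again without a number. Among the measured compounds shown here, compound 2 is thus the only member with a reported half-maximal inhibitory concentration, and it stands on its own among entries that were not quantified.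

Compound 4 (`COC(=O)C1=C(C)NC(=O)NC1c1ccc(O)cc1`) differs from compound 2 by a single change: hydrogen in place of methyl on an oxygen on an aromatic ring. For the measured compounds named here, no step between measured compounds shows what such a change does in this assay. Going by the values given here, with no comparable pair to lean on, the step from compound 2 to compound 4 is expected to stay within the scatter, a 1.0-fold higher number from compound 2 to compound 4 (0.01 log units; within the scatter), and compound 4 is estimated at 60000 nM, with a range from 20000 nM to 200000 nM.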

Compound 4, half-maximal inhibitory concentration: 17200 nM
Compound 4: middle estimate off by 3.5-fold (0.54 log units), on the high side; measured number outside the range, below it.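

Among the compounds shown here, replacing methyl with hydrogen on the oxygen on the aromatic ring gives a 3.4-fold lower number from compound 2 to compound 4 (0.54 log units; beyond the scatter) in this assay and is the first readable step, a modest one beyond the scatter. The position therefore responds to the change from methoxy to hydroxy, and the lower number goes with the hydroxy compound. Compound 1, with neither group on the ring, gives "not active" (no number reported) in the same assay, so both oxygen-bearing compounds with numbers stand apart from it, while compound 3 shows that an oxygen substituent alone does not ensure a number. No measurement at hand bears on the reason for the step.

On these data alone, whether an amine or a carboxylic acid in place of the hydroxy would lower the number further remains open. So does the effect of a longer chain, such as ethoxy or propoxy, on that same oxygen.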